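Nitro to methoxy in the amide series: expected inhibition

A few compounds are considered here, and "the series" means these few. Any claim that something is new, unique, unknown or untested is made for them only; others in the source may bear on it.

Compound 1 `CN(CC(=O)NCc1cnc2scc(-c3ccc(Br)cc3)n12)C(=O)c1ccccc1` gives 50% in an assay on isolated protein for inhibition of Indoleamine 2,3-dioxygenase 1 (Homo sapiens), with a stated time of 60 min, tested at 1 uM; a lower number here means less inhibition, a higher number more inhibition at the concentration tested (going by the name of the read-out).
Compound 2 `CN(CC(=O)NCc1cnc2scc(-c3ccc(Br)cc3)n12)C(=O)c1ccc(C#N)cc1` gives 47% in this assay.
Compound 3 `CN(CC(=O)NCc1cnc2scc(-c3ccc(Br)cc3)n12)C(=O)c1ccc([N+](=O)[O-])cc1` gives 45% in this assay.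

Compound 3 stands lowest of the three numbers, yet only within the scatter: a number 5 percentage points lower from compound 1 to compound 3 (within the scatter) and a number 2 percentage points lower from compound 2 to compound 3 (within the scatter).

Compound 4 `COc1ccc(C(=O)N(C)CC(=O)NCc2cnc3scc(-c4ccc(Br)cc4)n23)cc1` differs from compound 3 by methoxy in place of nitro on an aromatic carbon. Going by the values given here, no measured step covers this exchange itself; the nearest are the substituent exchanges at an aromatic carbon seen so far, a number 3 percentage points lower from compound 1 to compound 2 (within the scatter), a number 5 percentage points lower from compound 1 to compound 3 (within the scatter) and a number 2 percentage points lower from compound 2 to compound 3 (within the scatter), each within the scatter. A step of no more than the scatter in this assay is therefore expected, a number 2 percentage points higher from compound 3 to compound 4 (within the scatter). Compound 4 is estimated at 47%, with a range from 35% to 60%.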

Compound 4, a percentage reported as inhibition, at one concentration (the size of the read-out at that concentration, not a potency): 49%
Compound 4: the middle estimate sits 2 percentage points below what was measured; the range from low to high includes it.
By their numbers in this assay, from the lowest: compounds 3, 2, 4 and 1 (each within the scatter of the next).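

In this assay, methoxy at this aromatic carbon, para to a large group, leaves the number within the scatter of all three earlier compounds: a number 4 percentage points higher from compound 3 to compound 4 (within the scatter) and a number 2 percentage points higher from compound 2 to compound 4 (within the scatter) and a number 1 percentage points lower from compound 1 to compound 4 (within the scatter) are all small steps. Hydrogen, cyano, nitro and methoxy at this position therefore cannot be told apart in this read-out. No evidence at hand bears on this result.

Open, from the compounds shown here alone, is whether an amine, a carboxylic acid or a longer chain at this carbon would give a step beyond the scatter.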